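The compounds below may be only part of what the source reports. "The series", "measured", "known", "first", "only" and "open" are said of these compounds alone.

Measured so far in an ADME assay on S9 fraction from S9 cells (Zone of skin, Homo sapiens) for metabolic stability, read by HPLC, with a stated time of 180 min, tested at 0.5 uM; on this read-out higher numbers stand for a longer-lived compound and lower numbers for a shorter-lived compound: compound 1 `CCC/N=C1\S/C(=C\c2ccc(OC(C)=O)c(C)c2)C(=O)N1c1ccccc1C` gives 0.122 h, and compound 2 `CCC/N=C1\S/C(=C\c2ccc(OC(=O)CCOC)c(C)c2)C(=O)N1c1ccccc1C` gives 0.08 h.

Within the data shown here, compound 1 stands at one end of these two numbers, but its only neighbour is compound 2, and the step of a 1.5-fold lower number from compound 1 to compound 2 (0.18 log units; within the scatter) separates them by less than the scatter. Compound 3 `CCC/N=C1\S/C(=C\c2ccc(OC(C)=O)c(C(F)(F)F)c2)C(=O)N1c1ccccc1C` differs from compound 1 in one place: trifluoromethyl in place of methyl on an aromatic carbon. Among the measured compounds shown here, the single measured step concerns the ester chain, not the aromatic substituent, so no measured step bears directly on this change. Without such precedent, the half-life of compound 3 is expected to stay close to that of compound 1, with a step of a 1.0-fold lower number from compound 1 to compound 3 (0.01 log units; within the scatter) that is not beyond the scatter. Compound 3 is therefore estimated at 0.12 h, within a range from 0.05 h to 0.3 h.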

Compound 3, half-life: 0.138 h
Compound 3: middle estimate off by 1.2-fold (0.06 log units), on the low side, within the range that was stated.
By their numbers in this assay, from the lowest: compounds 2, 1 and 3 (each within the scatter of the next).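

In this assay, trifluoromethyl in place of methyl on this aromatic carbon, ortho to an acetoxy group, gives a 1.1-fold higher number from compound 1 to compound 3 (0.05 log units; within the scatter), so this place accepts four heavy atoms instead of one with the read-out staying within the scatter. Among these compounds, this is the first step at the aromatic substituent, the earlier one having concerned the ester chain, and no measurement offered here accounts for the result.

On these data alone, whether chloro, methoxy or a nitrile at this place would also stay within the scatter of compound 1 remains open. So does whether trifluoromethyl would behave alike alongside the longer ester chain of compound 2.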